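Ring-carbon substituent exchange in a macrocycle series

This account rests on a few compounds, and the source may have more. Where it says the series, first, only, none or still open, it means among the compounds named here.

Measured compounds:
compound 1 `CC(C)=CCC[C@]1(C)/C=C/[C@@H](OC(=O)C=C(C)C)[C@](C)(O)/C=C/C(=O)/C(CCl)=C\C1` — 390 nM
compound 2 `CC[Si](CC)(CC)C/C1=C/C[C@](C)(CCC=C(C)C)/C=C/[C@@H](OC(=O)C=C(C)C)[C@](C)(O)/C=C/C1=O` — 2690 nM

In a functional assay on SW480 cells (Homo sapiens) for antiproliferative activity, read by MTT assay, with a stated time of 48 h (a higher number here means a weaker inhibitor, a lower number a stronger inhibitor), compound 1 gives 390 nM. For the measured compounds named here, compound 2 gives 2690 nM in this assay, the highest of the two numbers so far; the single measured step, a 6.9-fold higher number from compound 1 to compound 2 (0.84 log units; beyond the scatter), lies beyond the scatter. Compound 3 `CC(C)=CCC[C@]1(C)/C=C/[C@@H](OC(=O)C=C(C)C)[C@](C)(O)/C=C/C(=O)/C(C(=O)N(C(C)C)C(C)C)=C\C1` is the next unmeasured member and differs from compound 2 in one place: a group of 9 heavy atoms (7 carbon, 1 nitrogen, 1 oxygen; no ring) in place of a group of 8 heavy atoms (7 carbon, 1 silicon; no ring), on a double-bonded ring carbon.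

Going by the values given here, no measured step covers a diisopropylcarbamoyl group at this double-bonded ring carbon. Among the compounds with values here, the only step at the same site, a 6.9-fold higher number from compound 1 to compound 2 (0.84 log units; beyond the scatter), was modest and went toward weaker inhibition; it shows the site is sensitive to what sits there, but gives no direction for this particular exchange. The expected step is therefore a 1.8-fold lower number from compound 2 to compound 3 (0.25 log units; within the scatter), with wide uncertainty that spans both measured values. Compound 3 is estimated at 1500 nM in this assay, with a range of 400 nM to 6000 nM.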

Compound 3, half-maximal inhibitory concentration: 16000 nM
For compound 3 the middle estimate is 11-fold (1.03 log units) below the measured one; measured number above the stated range.
By their numbers in this assay, from the lowest: compound 1; then compound 2; then compound 3.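

In this assay a second exchange at this double-bonded ring carbon also moves toward weaker inhibition, with a 5.9-fold higher number from compound 2 to compound 3 (0.77 log units; beyond the scatter), so the carbon bearing the triethylsilylmethyl group of compound 2 is not the low point of the series. Set directly against the chloromethyl group, diisopropylcarbamoyl gives a 41-fold higher number from compound 1 to compound 3 (1.61 log units; beyond the scatter), and the three groups fall in one order, with chloromethyl lowest and diisopropylcarbamoyl highest. Nothing available accounts for this order.

Open, going by these compounds, is whether any group at this carbon matches or improves on chloromethyl, for instance bromomethyl, hydroxymethyl, or a smaller unsubstituted carboxamide. A carboxylic acid or a dimethylamide would also show whether the loss follows the carbonyl itself or the two isopropyl groups on nitrogen.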